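The compounds below may be only part of what the source reports. "The series", "measured", "known", "first", "only" and "open" are said of these compounds alone.

Measured so far:
- Compound 1, `COc1cc2c(Oc3ccc(NC(=O)c4cc(-c5ccccc5F)ccn4)cc3F)ccnc2cc1OCCCN1CCCCC1`: in a functional assay on A549 cells (Homo sapiens) for cytotoxicity, read by MTT assay, with a stated time of 72 h (a lower number here means a stronger inhibitor, a higher number a weaker inhibitor), compound 1 gives "not determined" (no result reported), so no result was reported.
- Compound 2, `COc1cc2c(Oc3ccc(NC(=O)c4cc(-c5ccc(C)cc5)ccn4)cc3F)ccnc2cc1OCCCN1CCCC1`: in this assay compound 2 gives 1060 nM.

Among the compounds with values here, compound 2 is therefore the only compound with a number here; compound 1 shares most of its structure but has no result in this assay, so there is nothing to compare it with. Within the data shown here, no step between two measured compounds is available, which means the size of any effect of changing the group on the shared core is unknown from these data.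

Compound 3, `COc1cc2c(Oc3ccc(NC(=O)c4cc(-c5ccccc5F)ccn4)cc3F)ccnc2cc1OCCCN1CCCC1`, differs from compound 2 in one place: 2-fluorophenyl in place of 4-methylphenyl on an aromatic carbon. Both groups have the same count of heavy atoms and neither carries a donor, an acceptor or a charge, so on the information given there is no basis to expect a step in this assay beyond the usual scatter in either direction. The estimate for compound 3 in this assay is 1300 nM, with a range from 450 nM to 4000 nM, which corresponds to an expected step of a 1.2-fold higher number from compound 2 to compound 3 (0.09 log units; within the scatter).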

Compound 3, half-maximal inhibitory concentration: 430 nM
Compound 3: middle estimate off by 3.0-fold (0.48 log units), on the high side; the whole stated range lies above it.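

In this assay the change from 4-methylphenyl to 2-fluorophenyl, on the aromatic carbon opposite the ring nitrogen, gives a 2.5-fold lower number from compound 2 to compound 3 (0.39 log units; beyond the scatter) and so moves the result beyond the usual scatter, towards a stronger inhibitor. Within the data shown here, the earlier compounds could not show this, since they offered only one number and no step, whereas this position now responds to a swap between two groups with the same count of heavy atoms, neither of which carries a donor, an acceptor or a charge. Those counts therefore did not foretell the step, and nothing measured here speaks to why the number moved.

A single pair also cannot separate the gain of the fluorine from the loss of the methyl or from the shift in where the substituent sits on the phenyl ring, so plain phenyl, 4-fluorophenyl and 2-methylphenyl would each be needed to pull these apart. As far as these compounds go, it also remains open whether this position would tolerate something quite different, such as a phenyl ring bearing an amine or a carboxylic acid.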